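Swapping azetidin-1-yl for dipropylamino on the shared core

A few compounds are considered here, and "the series" means these few. Any claim that something is new, unique, unknown or untested is made for them only; others in the source may bear on it.

Values so far in a functional assay on HeLa cells (Homo sapiens) for inhibition, read by sulforhodamine B assay; a lower number here means a stronger inhibitor, a higher number a weaker inhibitor:
compound 1 (`CCc1ccc(NC2=CC(=O)c3c(nc4n3[C@H]3OC[C@@H](O)[C@H]3OC4)C2=O)cc1`) : 6510 nM
compound 2 (`O=C1C(N2CCC2)=CC(=O)c2c1nc1n2[C@H]2OC[C@@H](O)[C@H]2OC1`) : > 16000 nM

Compound 2 stands at the limit of > 16000 nM in this assay, at which 1 of the 2 values shown sits, so its reading is a limit and not a number. Compound 3 (`CCCN(CCC)C1=CC(=O)c2c(nc3n2[C@H]2OC[C@@H](O)[C@H]2OC3)C1=O`) keeps the shared core and changes one group: dipropylamino replaces azetidin-1-yl on a double-bonded ring carbon (dipropylamino in place of azetidin-1-yl on a double-bonded ring carbon). Among the measured compounds shown here, only one measured step touches this place, and it bears on the change only loosely, since it involves (4-ethylphenyl)amino and not dipropylamino. That step runs an at least 2.4-fold higher number from compound 1 to compound 2 (0.39 log units; beyond the scatter) and shows that the group at this place can move the number. For the measured compounds named here, no measured step gives the effect of dipropylamino directly. A modest move toward a lower number is therefore expected in this assay, although no change beyond the scatter is also quite possible, and compound 3 may again return only a limit. The expected step is an at least 1.4-fold lower number from compound 2 to compound 3 (0.16 log units; that floor lies within the scatter). This estimate is rough because it starts from compound 2 at the limit > 16000 nM. In this assay the estimate for compound 3 is 11000 nM, with the value expected between 4000 nM and 30000 nM in most repeats.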

Compound 3, half-maximal inhibitory concentration: > 16000 nM
Compound 3: a limit, no number; the forecaster's own chance of this, stated with the estimate: 45%; at least 1.4-fold (0.16 log units) between middle value and limit.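

In this assay, compound 3 gives > 16000 nM, which is a limit of the assay and not a number. Dipropylamino in place of (4-ethylphenyl)amino gives an at least 2.4-fold higher number from compound 1 to compound 3 (0.39 log units; beyond the scatter), so the higher number seen with azetidin-1-yl is not tied to that four-membered ring, since the ring-free dipropylamino group also reads higher than compound 1. Compound 2 and compound 3 cannot be ranked against each other, and the step between them cannot be read, as both stand at the same reading: the limit of > 16000 nM in this assay, at which 2 of the 3 values shown sit.

On these data alone, whether azetidin-1-yl and dipropylamino truly differ remains open, as any difference would lie beyond the reach of this reading. As far as these compounds go, how phenylamino or propylamino would read on the shared core also stays open, and with it whether the ethyl group, the phenyl ring or the hydrogen on the nitrogen goes with the lower number of compound 1, which gives 6510 nM.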